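Cytotoxicity notes on a shared core series

The compounds below may be only part of what the source reports. "The series", "measured", "known", "first", "only" and "open" are said of these compounds alone.

Measured so far:
Compound 1, `Cc1ccc(-c2ccc(F)cc2)n1-c1ccc(-c2nc3ccc(F)cc3s2)cc1`: in an ADME assay on MCF-10A cells (Homo sapiens) for cytotoxicity, read by MTT assay, with a stated time of 72 h (a lower number here means a stronger inhibitor, a higher number a weaker inhibitor), compound 1 gives 37800 nM.
Compound 2, `COc1ccc2nc(-c3ccc(-n4c(C)ccc4-c4ccc([N+](=O)[O-])cc4)cc3)sc2c1`: in this assay compound 2 gives 34900 nM.
Compound 3, `COc1cc2nc(-c3ccc(-n4c(C)ccc4-c4ccc(C)cc4)cc3)sc2c(OC)c1OC`: in this assay compound 3 gives 42500 nM.

The three numbers sit close together. The values of compound 1 and compound 2 both lie within the usual scatter of the value for compound 3, so nothing separates compound 3 from the other two; the series as a whole shows weak cytotoxicity on these cells.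

Compound 4, `COc1cc2nc(-c3ccc(-n4c(C)ccc4-c4ccc(F)cc4)cc3)sc2c(OC)c1OC`, shares the core of compound 3 and differs from it in one place: fluoro in place of methyl on an aromatic carbon. Within the data shown here, no pair of measured compounds differs in a single place, so no measured step is available for this change. Compound 1, which also carries a 4-fluorophenyl group, gives a number within the scatter of compound 3 despite a different core. On that basis the step from compound 3 to compound 4 is expected to stay within the scatter in either direction, estimated as a 1.1-fold lower number from compound 3 to compound 4 (0.03 log units; within the scatter). Compound 4 is therefore expected to give about 40000 nM in this assay, with a range from 20000 nM to 80000 nM.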

Compound 4, half-maximal inhibitory concentration: 43200 nM
Compound 4: the middle estimate sits 1.1-fold (0.03 log units) below what was measured; the measured number falls inside the stated range.
By their numbers in this assay, from the lowest: compounds 2, 1, 3 and 4 (each within the scatter of the next).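

Among these compounds, until now no pair differing in one place was available, so this position had no direct reading. Among the compounds shown here, the step of a 1.0-fold higher number from compound 3 to compound 4 (0.01 log units; within the scatter) in this assay is the first such reading, and it leaves 4-methylphenyl and 4-fluorophenyl indistinguishable at this position, on a carbon para to a large group. No supporting measurement bears on the reason for this result.

Still open, from the compounds shown here alone, is whether any group at this position can move the number beyond the scatter, for example an amine, a carboxylic acid or a longer chain in place of the methyl. Also open, going by these compounds, is whether the same exchange of methyl for fluoro reads the same way on a different core.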